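From tert-butyl to 3-methoxyphenyl on a shared core

This account rests on a few compounds, and the source may have more. Where it says the series, first, only, none or still open, it means among the compounds named here.

Measured in a functional assay on AGS cells (Homo sapiens) for inhibition, read by reporter gene assay; a higher number here means a weaker inhibitor, a lower number a stronger inhibitor:
- Compound 1 `CC(C)(C)c1ccc(OCC(=O)Nc2cccc(C(=O)O)c2)cc1`: 9500 nM
- Compound 2 `NC(=O)c1cccc(NC(=O)COc2ccccc2)c1`: > 30000 nM, a limit

In this assay, for the measured compounds named here, compound 1 gives the only actual number so far, 9500 nM. For compound 2, the result of > 30000 nM is a limit and not a number.

Compound 3 `COc1cccc(-c2ccc(OCC(=O)Nc3cccc(C(=O)O)c3)cc2)c1` keeps the core of compound 1 and changes one group, with 3-methoxyphenyl in place of tert-butyl on an aromatic carbon, para to a large group: 3-methoxyphenyl in place of tert-butyl on an aromatic carbon. Going by the values given here, no measured pair shows what such an exchange does, so the expectation starts from compound 1 at 9500 nM and is necessarily loose. A modest move towards stronger inhibition is expected, with an estimated 3.2-fold lower number from compound 1 to compound 3 (0.50 log units; beyond the scatter). In this assay, the estimate for compound 3 is 3000 nM, expected to lie between 700 nM and 13000 nM.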

Compound 3, half-maximal inhibitory concentration: 35000 nM
Beside the measured number, compound 3's estimate is 12-fold (1.07 log units) below it; the whole stated range lies below it.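

In this assay, this is the first exchange shown on this aromatic carbon, para to a large group, and it gives a 3.7-fold higher number from compound 1 to compound 3 (0.57 log units; beyond the scatter). The position therefore responds to what it carries, and here the 3-methoxyphenyl group, with more heavy atoms than tert-butyl plus an aromatic ring and a hydrogen-bond acceptor, gives weaker inhibition. Compound 2 stands at a limit and not a number, which is a reminder that compound 3 reads in the same high region of the assay: the limit of > 30000 nM in this assay, at which 1 of the 3 values shown sits.

The compounds shown leave open whether the weakening follows from the added ring itself or from the methoxy group on it, which a plain phenyl at this place would help to separate. They also do not show how a smaller group, such as methyl or chlorine, would read here.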